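Branching the acyl chain of the acylsulfonamide

A few compounds are considered here, and "the series" means these few. Any claim that something is new, unique, unknown or untested is made for them only; others in the source may bear on it.

Measured so far, in an assay for binding affinity to Type-2 angiotensin II receptor (Rattus norvegicus); on this read-out higher numbers stand for weaker inhibition and lower numbers for stronger inhibition:
compound 1, `CCc1nc2c(C)cc(C)nc2n1Cc1ccc(-c2ccccc2S(=O)(=O)NC(C)=O)cc1`, gives a value that is a limit of the assay, > 10000 nM.
compound 2, `CCCC(=O)NS(=O)(=O)c1ccccc1-c1ccc(Cn2c(CC)nc3c(C)cc(C)nc32)cc1`, gives 3600 nM.

Among the compounds with values here, compound 2 thus holds the only number in this assay; the other value shown is a limit. Within the data shown here, the single measured step, an at least 2.7-fold lower number from compound 1 to compound 2 (0.44 log units; beyond the scatter), lengthens the acyl chain; its size is bounded only by the limit of > 10000 nM in this assay, at which 1 of the 2 values shown sits, so its true size is not known.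

Compound 3, `CCc1nc2c(C)cc(C)nc2n1Cc1ccc(-c2ccccc2S(=O)(=O)NC(=O)C(C)C)cc1`, differs from compound 2 by isopropyl in place of propyl on a carbonyl carbon. Among the measured compounds shown here, no measured step covers branching of the acyl chain; the lengthening step gives a weak hint that the acyl chain matters, but not which way branching moves the number. A step of a 1.0-fold lower number from compound 2 to compound 3 (0.01 log units; within the scatter) is therefore expected, within the scatter. Compound 3 is estimated at 3500 nM in this assay, between 1200 nM and 10000 nM.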

Compound 3, half-maximal inhibitory concentration: 1800 nM
Beside the measured number, compound 3's estimate is 1.9-fold (0.29 log units) above it; the range from low to high includes it.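

Branching at this position leaves the number where it was in this assay: the change from propyl to isopropyl on the carbonyl carbon gives a 2.0-fold lower number from compound 2 to compound 3 (0.30 log units; within the scatter) and so does not separate the two chains. Isopropyl in place of methyl on the same carbon gives an at least 5.5-fold lower number from compound 1 to compound 3 (0.74 log units; beyond the scatter) in this series, so a branched chain, like the straight propyl, stands clear of methyl. On these data alone, the true size of that step remains unknown: the limit of > 10000 nM in this assay, at which 1 of the 3 values shown sits.

Still open, as far as these compounds go, is whether a longer chain such as pentyl, or a bulkier group such as tert-butyl or phenyl on the carbonyl carbon, moves the number beyond the scatter. Also open, from the compounds shown here alone, is whether the acyl chain matters to the same extent with another group in place of the ethyl on the shared core.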